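A few compounds are considered here, and "the series" means these few. Any claim that something is new, unique, unknown or untested is made for them only; others in the source may bear on it.

In a functional assay on A549 cells (Homo sapiens) for cytotoxicity, read by MTT assay, with a stated time of 72 h (on this read-out higher numbers stand for weaker inhibition and lower numbers for stronger inhibition), two compounds have been measured so far. Compound 2 (`CN(C)CCCCn1c2c(c3ccccc31)C(=O)c1c[n+]([O-])c3ccccc3c1C2=O`) reads 310 nM and holds the lower of the two numbers, while compound 1 (`O=C1c2c[n+]([O-])c3ccccc3c2C(=O)c2c1c1ccccc1n2CCN1CCCCC1`) reads 1080 nM on the same shared core. Compound 3 (`O=C1c2c[n+]([O-])c3ccccc3c2C(=O)c2c1c1ccccc1n2Cc1cn(C[C@@H](O)CO)nn1`) alters the side chain of compound 2: 1-(2,3-dihydroxypropyl)-1H-1,2,3-triazol-4-yl in place of 3-(dimethylamino)propyl on a saturated chain carbon bound to an aromatic nitrogen in all. Its dimethylamino end is gone, and a triazole ring bearing a diol stands in its place. Among the measured compounds shown here, only one measured step bears on this, a 3.5-fold lower number from compound 1 to compound 2 (0.54 log units; beyond the scatter) and that modest step exchanged a piperidin-1-yl end for a dimethylamino end. For the measured compounds named here, no measured compound carries the new group, so this guide is loose. A move of similar size towards weaker inhibition is expected, with the estimated step being a 3.5-fold higher number from compound 2 to compound 3 (0.55 log units; beyond the scatter) and its uncertainty wide. In this assay the estimate for compound 3 is 1100 nM with an expected range from 350 nM to 3500 nM as the likely span.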

Compound 3, half-maximal inhibitory concentration: 390 nM
For compound 3 the middle estimate is 2.8-fold (0.45 log units) above the measured one, within the range that was stated.
By their numbers in this assay, from the lowest: compounds 2 and 3 (each within the scatter of the next); then compound 1.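

In this assay, the exchange at this saturated chain carbon bound to an aromatic nitrogen gives a 1.3-fold higher number from compound 2 to compound 3 (0.10 log units; within the scatter), so among these compounds a side chain ending in dimethylamino and one carrying a triazole ring with a diol read alike, and a basic amine end is not needed to reach this level. Compound 1, with its piperidin-1-yl end, stands apart from the triazole, with a 2.8-fold lower number from compound 1 to compound 3 (0.44 log units; beyond the scatter), so having an amine end does not by itself set the number here. No measurement given here explains either step.

Whether the triazole ring or the diol accounts for the reading remains open, as does what a 1-methyl-1H-1,2,3-triazol-4-yl group would give. The effect of the opposite configuration at the defined stereocentre is also unknown.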